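This account rests on a few compounds, and the source may have more. Where it says the series, first, only, none or still open, it means among the compounds named here.

Compounds measured so far:

Compound 1, `COc1cc(/C=C/C(=O)C2=C(/C=C/c3ccc(O)c(OC)c3)NC(=O)NC2c2ccccc2O)ccc1O`, gives 29.9% in a functional assay, with a stated time of 20 min, tested at 2 uM; on this read-out lower numbers stand for a weaker effect and higher numbers for a stronger effect at the one concentration tested.
Compound 2, `COc1cc(/C=C/C(=O)C2=C(/C=C/c3ccc(O)c(OC)c3)NC(=O)NC2c2ccc(N(C)C)cc2)ccc1O`, gives 28.2% in this assay.
Compound 3, `COc1cc(/C=C/C(=O)C2=C(/C=C/c3ccc(O)c(OC)c3)NC(=S)NC2c2ccccc2O)ccc1O`, gives 34% in this assay.

The three measured compounds sit close together. Compound 2 differs from compound 1 in one place, (4-(dimethylamino)phenyl in place of 2-hydroxyphenyl on a saturated ring carbon), and this change produced a step of a number 1.7 percentage points lower from compound 1 to compound 2 (within the scatter). Compound 3 stands at the highest of the three numbers, but its gaps to compound 1 and to compound 2 are both within the scatter, so no order among the three can be read from these values. How the core of compound 3 differs from the core of compound 1 is not broken down here.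

Compound 4, `COc1cc(/C=C/C(=O)C2=C(/C=C/c3ccc(O)c(OC)c3)NC(=S)NC2c2ccc(N(C)C)cc2)ccc1O`, has not yet been measured in this assay. It differs from compound 3 by 4-(dimethylamino)phenyl in place of 2-hydroxyphenyl on a saturated ring carbon. The place of this change is described in the same words as for the change from compound 1 to compound 2, so it is the same change carried onto the core of compound 3. The step from compound 3 to compound 4 is expected to be a number 1.7 percentage points lower from compound 3 to compound 4 (within the scatter), a size resting on the earlier pair because a number 1.7 percentage points lower from compound 1 to compound 2 (within the scatter) lay within the scatter. On that basis compound 4 is expected to give about 32.3% in this assay, estimated to fall between 22% and 42%.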

Compound 4, a percentage reported as activity, at one concentration (the size of the read-out at that concentration, not a potency): 32.3%
Estimate against measurement, compound 4: no gap at the digits printed, and the stated range covers the measured number.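

In this assay, replacing 2-hydroxyphenyl with 4-(dimethylamino)phenyl on the saturated ring carbon gave a number 1.7 percentage points lower from compound 3 to compound 4 (within the scatter) and so matched the step already seen on the core of compound 1, with the two cores showing no difference in how they took up this change: the same change on two cores in this assay, a number 1.7 percentage points lower (within the scatter) from compound 1 to compound 2 and a number 1.7 percentage points lower (within the scatter) from compound 3 to compound 4, 0 percentage points apart, within the scatter of two such steps. This shows that, for this one swap and these two cores, a step read on one core correctly described the step on the other. It does not show that steps in general carry over in this series, since both steps lie within the scatter, so the agreement is between two changes too small to read, and a change with a step beyond the scatter could behave differently from one core to the other.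

The compounds shown hold only 2-hydroxyphenyl and 4-(dimethylamino)phenyl on that ring carbon, so it stays open whether a phenyl ring bearing a carboxylic acid, a halogen or a longer alkyl chain there would move the read-out beyond the scatter and carry over in the same way. Also open, as far as these compounds go, is how these four compounds would compare at any concentration other than the single one tested, since the read-out is not a potency.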